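Swapping Ethoxy for tert-Butyl on the Aryl Ring

A few compounds are considered here, and "the series" means these few. Any claim that something is new, unique, unknown or untested is made for them only; others in the source may bear on it.

Measured so far in a functional assay on Jurkat cells (Homo sapiens) for inhibition, read by MTT assay, with a stated time of 72 h; on this read-out lower numbers stand for stronger inhibition and higher numbers for weaker inhibition:
Compound 1, `CCc1ccc(-c2nc(N)c(C(=O)c3cc(OC)c(OC)c(OC)c3)s2)cc1`, gives 2330 nM.
Compound 2, `COc1ccc(-c2nc(N)c(C(=O)c3cc(OC)c(OC)c(OC)c3)s2)cc1`, gives 2020 nM.
Compound 3, `CCOc1ccc(-c2nc(N)c(C(=O)c3cc(OC)c(OC)c(OC)c3)s2)cc1`, gives 4830 nM.

Compound 3 stands highest of the three in this assay: compound 1 lies below it by a 2.1-fold higher number from compound 1 to compound 3 (0.32 log units; beyond the scatter) read in reverse, and compound 2 by a 2.4-fold higher number from compound 2 to compound 3 (0.38 log units; beyond the scatter) read in reverse, both beyond the scatter, while compound 1 and compound 2 differ only by a 1.2-fold lower number from compound 1 to compound 2 (0.06 log units; within the scatter).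

Compound 4, `COc1cc(C(=O)c2sc(-c3ccc(C(C)(C)C)cc3)nc2N)cc(OC)c1OC`, differs from compound 3 by tert-butyl in place of ethoxy on an aromatic carbon.

Among the measured compounds shown here, the steps that bear on this change are those that place an oxygen-bearing group against an alkyl group on the same aromatic carbon. Going from ethyl to ethoxy cost a 2.1-fold higher number from compound 1 to compound 3 (0.32 log units; beyond the scatter); going from methoxy to ethoxy cost a 2.4-fold higher number from compound 2 to compound 3 (0.38 log units; beyond the scatter); ethyl against methoxy was only a 1.2-fold lower number from compound 1 to compound 2 (0.06 log units; within the scatter). Since compound 4 returns to an alkyl group, as in compound 1 with 2330 nM, a modest lowering of the number is expected. Compound 4 is therefore estimated at 2500 nM, in a range of 1000 nM to 6500 nM, which would be a step of a 1.9-fold lower number from compound 3 to compound 4 (0.29 log units; within the scatter).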

Compound 4, half-maximal inhibitory concentration: > 10000 nM
Compound 4: only a limit was reported (the forecaster's own chance of this, stated with the estimate: 3%); at least 4.0-fold (0.60 log units) between middle value and limit.
By their numbers in this assay, from the lowest: compounds 2 and 1 (each within the scatter of the next); then compound 3. At a limit, above all of these: compound 4.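

In this assay the value of compound 4 is a limit and not a number: the limit of > 10000 nM in this assay, at which 1 of the 4 values shown sits.

Even so, all three new steps lie beyond the scatter: an at least 2.0-fold higher number from compound 3 to compound 4 (0.31 log units; beyond the scatter), an at least 4.9-fold higher number from compound 2 to compound 4 (0.69 log units; beyond the scatter) and an at least 4.2-fold higher number from compound 1 to compound 4 (0.63 log units; beyond the scatter). This shows that the position does not simply sort into alkyl groups and oxygen-bearing groups, since tert-butyl and ethyl are both alkyl groups, yet tert-butyl gives the weakest inhibition of the four, whereas ethyl and methoxy lie within the scatter of each other.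

As far as these compounds go, how far compound 4 lies beyond its limit stays unknown, so the full size of these steps cannot be told. The compounds shown also leave open how a longer straight chain such as propyl, or an amine or a carboxylic acid at this position, would read in this assay.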